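This account rests on a few compounds, and the source may have more. Where it says the series, first, only, none or still open, it means among the compounds named here.

Three compounds of a shared core were measured in an assay on THP-1 cells for displacement of a labelled ligand from C-C chemokine receptor type 1 (Homo sapiens); on this read-out lower numbers stand for stronger inhibition and higher numbers for weaker inhibition. Compound 1 `Cc1ccc(CCC(=O)N[C@@H](C(=O)N2CCC(c3ccc(Cl)cc3)CC2)C(C)C)cc1` gives 105 nM, the lowest of the three numbers, yet its gaps to compound 2 and compound 3 lie within the scatter, so no ranking among them is claimed. Compound 2 `O=C(N[C@@H](C(=O)N1CCC(c2ccc(Cl)cc2)CC1)C1CCCCC1)c1ccccc1` gives 121 nM in this assay, and compound 3 `CCCC(NC(=O)c1ccccc1C)C(=O)N1CCC(c2ccc(Cl)cc2)CC1` gives 152 nM. Compound 4 `CC(C)[C@@H](NC(=O)c1ccc(F)c(F)c1)C(=O)N1CCC(c2ccc(Cl)cc2)CC1` has not been measured; it differs from compound 1 by 3,4-difluorophenyl in place of 2-(4-methylphenyl)ethyl on a carbonyl carbon. Compound 2 and compound 3, which also carry an aromatic ring directly on that carbonyl carbon, show values close to that of compound 1, so the step from compound 1 to compound 4 is expected to stay within the scatter, with a 1.0-fold higher number from compound 1 to compound 4 (0.02 log units; within the scatter). Compound 4 is therefore estimated at 110 nM, within a range from 40 nM to 300 nM.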

Compound 4, half-maximal inhibitory concentration: 14 nM
Compound 4: the middle estimate sits 7.9-fold (0.90 log units) above what was measured; measured number outside the range, below it.
By their numbers in this assay, from the lowest: compound 4; then compounds 1, 2 and 3 (each within the scatter of the next).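

In this assay, 3,4-difluorophenyl in place of 2-(4-methylphenyl)ethyl on a carbonyl carbon gives a 7.5-fold lower number from compound 1 to compound 4 (0.88 log units; beyond the scatter), so this position can move the number beyond the scatter, which the earlier compounds, lying within the scatter of one another, had not shown. Both groups hold one six-membered aromatic ring of carbon only and no hydrogen-bond donors or acceptors, so those counts do not separate them. No measurement shown bears on why the number falls. Open, as far as these compounds go, is how a plain phenyl or a 2-(3,4-difluorophenyl)ethyl on that carbonyl carbon would read, and so whether the step goes with the two fluorines or with the loss of the ethyl link.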